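Chloro for methoxy on the shared core

The compounds below may be only part of what the source reports. "The series", "measured", "known", "first", "only" and "open" are said of these compounds alone.

In a physicochemical assay for solubility, read by HPLC, at pH 7.4 (on this read-out higher numbers stand for higher solubility and lower numbers for lower solubility), compound 1 `Cc1[nH]c2ccccc2c(=O)c1C1CCCCC1` reads 10000 nM and compound 2 `COc1ccc2nc(C)c(Cc3ccccc3)c(OC)c2c1` reads 2000 nM as the lower of the two numbers, a gap beyond the scatter. Compound 3 `COc1c(Cc2ccccc2)c(C)nc2ccc(Cl)cc12` has chloro in place of methoxy on an aromatic carbon of the core of compound 2. Within the data shown here, no measured pair differs in one place, so the expectation rests on the structural change alone. A modest fall in this assay is expected, estimated as a 2.5-fold lower number from compound 2 to compound 3 (0.40 log units; beyond the scatter) and only slightly beyond the scatter. Compound 3 is expected at 800 nM (estimated range 250 nM to 2500 nM).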

Compound 3, solubility: < 2000 nM
Compound 3: a limit, no number; the forecaster's own chance of this, stated with the estimate: 5%; the middle value is on the limit's open side.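

In this assay compound 3 gives < 2000 nM, a limit of the assay and not a number. Chloro in place of methoxy on an aromatic carbon gives a number no higher from compound 2 to compound 3 (the limit leaves the size open). Among these compounds, this is the first step that differs in one place, and all it shows for this position is the direction allowed by the limit, with no size.

From the compounds shown here alone, how far compound 3 lies from compound 2 stays open. Also open, going by these compounds, is how an amine, a carboxylic acid or ethoxy would read at this position.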